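A few compounds are considered here, and "the series" means these few. Any claim that something is new, unique, unknown or untested is made for them only; others in the source may bear on it.

Measured so far:

- compound 1 `CCn1c(=O)/c(=C2\Sc3ccccc3N2C)s/c1=C\c1ccncc1Nc1ccccc1Cl`: 750 nM
- compound 2 `CCn1c(=O)/c(=C2\Sc3cc(F)ccc3N2C)s/c1=C\c1ccncc1Nc1ccccc1C`: 1300 nM

Both compounds were tested in a functional assay on MCF7 cells (Homo sapiens) for inhibition; on this read-out higher numbers stand for weaker inhibition and lower numbers for stronger inhibition. Compound 1 gives 750 nM and compound 2 gives 1300 nM in this assay. Compound 2 stands at the upper end of the two numbers, but the gap to compound 1 is within the usual scatter, so the two cannot be told apart on these data.

Compound 3 `CCn1c(=O)/c(=C2\Sc3cc(F)ccc3N2C)s/c1=C\c1ccncc1Nc1ccccc1Cl` is to be measured in this assay. It differs from compound 2 in one place: chloro in place of methyl on an aromatic carbon. The amine-bearing ring thus carries chloro in place of methyl, as in compound 1, while the fluoro on the shared core is kept as in compound 2. Among the compounds with values here, no pair of measured compounds isolates this exchange, and compounds 1 and 2 differ in two places, so their values give no clean step to lean on.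

The step from compound 2 to compound 3 is expected to be small, a 1.4-fold lower number from compound 2 to compound 3 (0.14 log units; within the scatter), not clearly beyond the scatter. Compound 3 is estimated at 950 nM in this assay, with a range of 400 nM to 2200 nM.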

Compound 3, half-maximal inhibitory concentration: 1300 nM
For compound 3 the middle estimate is 1.4-fold (0.14 log units) below the measured one; the range from low to high includes it.
By their numbers in this assay, from the lowest: compounds 1, 2 and 3 (each within the scatter of the next).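

Read in this assay, the exchange of 2-methylphenyl for 2-chlorophenyl, on an aromatic carbon ortho to a large group, gives no change at the digits printed from compound 2 to compound 3 (within the scatter), so methyl and chloro cannot be told apart at this position with the fluoro kept on the shared core. Within the data shown here, compound 3 also supplies the first pair that isolates fluoro in place of hydrogen on an aromatic carbon of that core, with a 1.7-fold higher number from compound 1 to compound 3 (0.24 log units; within the scatter), and this exchange likewise cannot be separated from repeat-measurement variation, whereas compounds 1 and 2 differ in two places and could not show either exchange alone. No independent data are available here that would explain either result.

The compounds shown leave open whether this position tolerates anything other than methyl and chloro, for example a methoxy group, an amine or a carboxylic acid in their place on the phenyl ring. On the shared core, the same question stands for chloro or methoxy in place of the fluoro, since only hydrogen and fluoro appear there so far.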